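A few compounds are considered here, and "the series" means these few. Any claim that something is new, unique, unknown or untested is made for them only; others in the source may bear on it.

Compound 1 `CC(=O)c1ccc2[nH]c(-c3ccc(C(F)(F)F)cc3)nc2c1` is the starting point. In an ADME assay on MDBK cells (Bos taurus) for cytotoxicity, read by MTT assay, with a stated time of 96 h (a higher number here means that more compound is tolerated, a lower number that less compound is tolerated), compound 1 gives > 100000 nM, which is a limit of the assay rather than a number. Compound 1 thus sits at the limit of > 100000 nM in this assay, at which 1 of the 2 values shown sits. Compound 2 `C/C(=N\O)c1ccc2[nH]c(-c3ccc(C(F)(F)F)cc3)nc2c1` gives 55000 nM in this assay, and the step of an at least 1.8-fold lower number from compound 1 to compound 2 (0.25 log units; that floor lies within the scatter) replaces the carbonyl with an oxime. Compound 3 `CC(=O)c1ccc2c(c1)nc(-c1ccc(C(F)(F)F)cc1)n2C1CCCCC1` differs from compound 1 by cyclohexyl in place of hydrogen on an aromatic nitrogen. No measured step touches that aromatic nitrogen, so the size of this change in this assay cannot be read from what is shown. Compound 3 is expected to give about 50000 nM (range 10000 nM to 150000 nM), a step of an at least 2.0-fold lower number from compound 1 to compound 3 (0.30 log units; that floor lies within the scatter) that carries wide uncertainty.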

Compound 3, half-maximal cytotoxic concentration: 52000 nM
Estimate against measurement, compound 3: 1.0-fold (0.02 log units) below, within the range that was stated.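

Among the compounds shown here, this is the first change on the aromatic nitrogen: in this assay, cyclohexyl in place of hydrogen gives an at least 1.9-fold lower number from compound 1 to compound 3 (0.28 log units; that floor lies within the scatter). A group this large on that nitrogen therefore yields a measurable value, but the step's floor does not establish a real loss of tolerance. Compound 1 stands at a limit rather than a number, so the true size of the step remains unknown: the limit of > 100000 nM in this assay, at which 1 of the 3 values shown sits.

As far as these compounds go, whether a small methyl or a chain ending in an amine or carboxylic acid on this nitrogen would give similar values remains open. So does the outcome of pairing cyclohexyl with the oxime.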